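Cytotoxicity series: para-halogen swap on a shared core

A few compounds are considered here, and "the series" means these few. Any claim that something is new, unique, unknown or untested is made for them only; others in the source may bear on it.

Measured in a functional assay on THP-1 cells (Homo sapiens) for cytotoxicity, read by MTT assay, with a stated time of 24 h; a higher number here means a weaker inhibitor, a lower number a stronger inhibitor:
compound 1, `COc1cc(/C=C2\CN(C)C/C(=C\c3ccc(F)cc3)C2=O)cc(OC)c1`: 5040 nM
compound 2, `COc1cc(/C=C2\CN(C)C/C(=C\c3ccc(Cl)cc3)C2=O)cc(OC)c1`: 5860 nM
compound 3, `CN1C/C(=C\c2ccc(F)cc2)C(=O)/C(=C/c2ccc(C#N)cc2)C1`: 5030 nM

Compound 2 differs from compound 1 by chloro in place of fluoro on an aromatic carbon; the step was a 1.2-fold higher number from compound 1 to compound 2 (0.07 log units; within the scatter). Compound 3 has a different core from compound 1; the difference between the two cores is not broken down here. All three values in this assay sit within the scatter of one another, so no order among them is read.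

Compound 4, `CN1C/C(=C\c2ccc(Cl)cc2)C(=O)/C(=C/c2ccc(C#N)cc2)C1`, not yet measured, differs from compound 3 by chloro in place of fluoro on an aromatic carbon. This is the same change as from compound 1 to compound 2, at the same kind of place. The expected step is a 1.2-fold higher number from compound 3 to compound 4 (0.06 log units; within the scatter), because the same change gave a 1.2-fold higher number from compound 1 to compound 2 (0.07 log units; within the scatter). Compound 4 is therefore expected to give about 5800 nM in this assay, estimated to fall between 3000 nM and 11000 nM.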

Compound 4, half-maximal inhibitory concentration: 3180 nM
For compound 4 the middle estimate is 1.8-fold (0.26 log units) above the measured one; the measured number falls inside the stated range.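

In this assay, the change from 4-fluorophenyl to 4-chlorophenyl gives a 1.6-fold lower number from compound 3 to compound 4 (0.20 log units; within the scatter). Set beside the earlier step, the two cores do not separate for this change: the same change on two cores in this assay, a 1.2-fold higher number (0.07 log units; within the scatter) from compound 1 to compound 2 and a 1.6-fold lower number (0.20 log units; within the scatter) from compound 3 to compound 4, 1.8-fold (0.26 log units) apart, within the scatter of two such steps. On both cores the change stays within the scatter, so the result fits a change that carries over with no readable effect, but it does not show a direction or size for the change on either core, nor that the cores respond alike beyond this one pair of halogens.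

The compounds shown leave open whether a bromo group, an amine or a carboxylic acid in the same place would move the number beyond the scatter. They also leave open whether any such group would behave alike on both cores.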